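Swapping One Fluoro Group on Compound 3

A few compounds are considered here, and "the series" means these few. Any claim that something is new, unique, unknown or untested is made for them only; others in the source may bear on it.

For the measured compounds named here, in an ADME assay on NIH3T3 cells (Mus musculus) for cytotoxicity, read by colorimetric assay and sulforhodamine B assay, with a stated time of 96 h (a lower number here means a stronger inhibitor, a higher number a weaker inhibitor), three related compounds have numbers so far. Compound 1 `COc1ccc(OC)c(/C=C/c2ccc(O)cc2)c1` gives 7400 nM. Compound 2 `Oc1cccc(/C=C/c2cc(O)c(F)c(O)c2)c1` reaches only a limit of the assay, > 30000 nM. Compound 3 `COc1cc(F)c(/C=C/c2cc(O)ccc2O)cc1O` gives 21100 nM, the higher of the two true numbers, and its gap to compound 1 lies beyond the usual scatter.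

Compound 4 `COc1ccc(/C=C/c2cc(O)ccc2O)cc1O` has not yet been measured. It differs from compound 3 in a single place: hydrogen in place of fluoro on an aromatic carbon, para to a hydroxy group (hydrogen in place of fluoro on an aromatic carbon). Going by the values given here, no measured pair shows this swap on its own, so its effect cannot be read directly from the data. Among the compounds with values here, the only guide is the spread of the numbers, with compound 1 at 7400 nM and compound 3 at 21100 nM, which suggests that a large move is unlikely. The expected change, a 1.4-fold lower number from compound 3 to compound 4 (0.15 log units; within the scatter), stays within the usual scatter and has no firm direction. For compound 4 the estimated value is 15000 nM, with an expected range from 6000 nM to 35000 nM.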

Compound 4, half-maximal inhibitory concentration: > 30000 nM
Compound 4 gave a limit, no number; the forecaster's own chance of this, stated with the estimate: 20%; middle value at least 2.0-fold (0.30 log units) away from the limit.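

In this assay compound 4 gives > 30000 nM, which is a limit of the assay and not a number. Putting hydrogen in place of fluoro on this aromatic carbon, para to a hydroxy group, gives an at least 1.4-fold higher number from compound 3 to compound 4 (0.15 log units; that floor lies within the scatter), so this swap can now be seen on its own, and at this position, losing the fluoro does not produce a stronger inhibitor. The true size of the step stays unknown, and it may or may not exceed the usual scatter, because the reading stops at a ceiling: the limit of > 30000 nM in this assay, at which 2 of the 4 values shown sit.

Only fluoro and hydrogen are shown at this position, so it remains open how a chloro group or an amine would behave there. This single pair also cannot tell whether the same swap would have a similar effect elsewhere on the shared core.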